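The source may report more compounds than this note shows. Statements on the series, on what has been measured and on what is new or still open speak of the compounds shown alone.

In a functional assay on MDA-MB-231 cells (Homo sapiens) for antiproliferative activity, read by sulforhodamine B assay (on this read-out lower numbers stand for stronger inhibition of growth and higher numbers for weaker inhibition of growth), the measured compounds are:
- compound 1 `CC(C)CCCOc1cccc(O)c1C(=O)/C=C/c1ccc(O)cc1`: 3480 nM
- compound 2 `O=C(/C=C/c1ccc(O)cc1)c1c(O)cccc1OCC1CCCCC1`: > 30000 nM (a limit)
- compound 3 `CCCCOc1cccc(O)c1C(=O)/C=C/c1ccc(O)cc1`: > 30000 nM (a limit)

Compound 3 therefore stands only at a limit, as the limit of > 30000 nM in this assay, at which 2 of the 3 values shown sit, shows. Compound 4 `CCC(CC)COc1cccc(O)c1C(=O)/C=C/c1ccc(O)cc1` differs from it by ethyl in place of hydrogen on a saturated chain carbon bound to two saturated chain carbons, which turns butyl into 2-ethylbutyl. For the measured compounds named here, two steps bear on this change: an at least 8.6-fold higher number from compound 1 to compound 3 (0.93 log units; beyond the scatter) and an at least 8.6-fold higher number from compound 1 to compound 2 (0.93 log units; beyond the scatter). The first suggests that a branched chain can restore a measurable value, while the second, with compound 2, goes against any general gain from branching. A modest shift towards a lower number in this assay is therefore expected, though compound 4 may stay at the limit. The expected step is an at least 1.6-fold lower number from compound 3 to compound 4 (0.22 log units; that floor lies within the scatter). For compound 4 the estimated value is 18000 nM, with an expected range from 6000 nM to 40000 nM.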

Compound 4, concentration for 50% growth inhibition: 3130 nM
Estimate against measurement, compound 4: 5.8-fold (0.76 log units) above; the whole stated range lies above it.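

In this assay, ethyl in place of hydrogen on the saturated chain carbon turns butyl into 2-ethylbutyl and brings a measurable value (an at least 9.5-fold lower number from compound 3 to compound 4 (0.98 log units; beyond the scatter)). Not every branch does this: pentan-3-yl in place of cyclohexyl also separates two compounds (an at least 9.5-fold lower number from compound 2 to compound 4 (0.98 log units; beyond the scatter)), while pentan-3-yl in place of isopentyl leaves no real difference (a 1.1-fold lower number from compound 1 to compound 4 (0.05 log units; within the scatter)). The first two steps start from limits, not numbers: the limit of > 30000 nM in this assay, at which 2 of the 4 values shown sit.

On these data alone, whether a longer chain, or an amine or a carboxylic acid on the chain, would keep a measurable value remains open.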